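Pyridinyl for methoxyphenyl on the thioether-linked chain

The source may report more compounds than this note shows. Statements on the series, on what has been measured and on what is new or still open speak of the compounds shown alone.

Three members of the series have been run in an assay on isolated protein for inhibition of aldehyde dehydrogenase 1A1 (Homo sapiens); on this read-out lower numbers stand for stronger inhibition and higher numbers for weaker inhibition. Compound 1 `COc1cccc(C(C)Sc2nc3c(cnn3C)c(=O)n2-c2ccccc2)c1` gives 451 nM in this assay, the second highest of the three numbers. Compound 2 `Cn1ncc2c(=O)n(-c3ccccc3)c(OCc3cccc(F)c3)nc21` gives 775 nM, which lies within the scatter of compound 1, so no order between the two can be read. For the measured compounds named here, compound 3 `CC(Sc1nc2nn(C3COC3)cc2c(=O)n1-c1ccccc1)c1cccnc1` gives 118 nM, the only number that stands beyond the scatter from compound 1; compound 3 differs from compound 1 in more than one place, so nothing in this set isolates a single change.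

Compound 4 `CC(Sc1nc2c(cnn2C)c(=O)n1-c1ccccc1)c1ccncc1` has not yet been measured in this assay. Relative to compound 1 the change is pyridin-4-yl in place of 3-methoxyphenyl on a saturated chain carbon bound to a saturated chain carbon and a sulfur. Going by the values given here, no single-change step is available to set its size, so the expectation rests on compound 3 at 118 nM carrying a pyridinyl on the same chain carbon. A step of a 1.7-fold lower number from compound 1 to compound 4 (0.24 log units; within the scatter) toward a lower number is expected, modest and possibly within the scatter. Compound 4 is estimated at 260 nM, expected to fall between 90 nM and 750 nM.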

Compound 4, half-maximal inhibitory concentration: 451 nM
Estimate against measurement, compound 4: 1.7-fold (0.24 log units) below; low and high end bracket the measured number.
By their numbers in this assay, from the lowest: compound 3; then compounds 1, 4 and 2 (each within the scatter of the next).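

For the compounds shown here, the first single-change step in this assay shows no change at the digits printed from compound 1 to compound 4 (within the scatter) for pyridin-4-yl in place of 3-methoxyphenyl on a saturated chain carbon bound to a saturated chain carbon and a sulfur. On the core of compound 1, this read-out therefore does not separate the two aromatic rings, and a pyridinyl at this position brings no readable gain by itself. No measurement on hand explains this outcome.

Compound 3 at 118 nM differs from compound 4 in more than one place, so the source of its number stays unassigned, and single changes would be needed to locate it. From the compounds shown here alone, it also remains open whether this position responds to anything further from these two rings, such as a piperidine ring or a carboxylic acid on the same chain carbon.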